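The source may report more compounds than this note shows. Statements on the series, on what has been measured and on what is new or still open speak of the compounds shown alone.

Working notes on the series.

Among the compounds with values here, compound 3 `CCn1c(=O)/c(=C2\Sc3cc(F)ccc3N2C)s/c1=C\c1ccncc1Nc1ccccc1C` gives 2300 nM in a functional assay on CWR22R cells (Homo sapiens) for inhibition (on this read-out lower numbers stand for stronger inhibition and higher numbers for weaker inhibition), the highest number of the three compounds measured so far. Compound 1 `CCn1c(=O)/c(=C2\Sc3cc(F)ccc3N2C)s/c1=C\c1ccncc1Nc1ccccc1F` gives 150 nM, and compound 2 `CCn1c(=O)/c(=C2\Sc3ccccc3N2C)s/c1=C\c1ccncc1Nc1ccccc1Cl` gives 460 nM; compound 2 differs from compound 3 both in the group on the anilino ring and in the core, so its value is noted without a step.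

The next compound, compound 4 `CCn1c(=O)/c(=C2\Sc3cc(F)ccc3N2C)s/c1=C\c1ccncc1Nc1ccccc1Cl`, carries the change (chloro in place of methyl on an aromatic carbon), the chloro taking the place of the methyl at the position ortho to a large group, giving (2-chlorophenyl)amino from (2-methylphenyl)amino.

Within the data shown here, the one step that bears on it is a 15-fold higher number from compound 1 to compound 3 (1.19 log units; beyond the scatter), where fluoro gave the lower number and methyl the higher one. Chloro is another halogen at the same position, and compound 2, which also carries chloro there, gives 460 nM. A move back toward the lower numbers of compound 1 and compound 2 is therefore expected, of roughly a 5.8-fold lower number from compound 3 to compound 4 (0.76 log units; beyond the scatter) in this assay. Compound 4 is estimated at 400 nM, within 150 nM to 1200 nM.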

Compound 4, half-maximal inhibitory concentration: 490 nM
Compound 4: the middle estimate sits 1.2-fold (0.09 log units) below what was measured, within the range that was stated.
By their numbers in this assay, from the lowest: compound 1; then compounds 2 and 4 (each within the scatter of the next); then compound 3.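

With the core of compound 1 held fixed, the group on the aromatic carbon ortho to a large group now gives three points in this assay, and chloro falls between the other two: a 3.3-fold higher number from compound 1 to compound 4 (0.51 log units; beyond the scatter) for chloro in place of fluoro, and a 4.7-fold lower number from compound 3 to compound 4 (0.67 log units; beyond the scatter) for chloro in place of methyl. Within the data shown here, the core change can also be read for the first time with the chloro held fixed, and fluoro in place of hydrogen on the core leaves the value within the scatter, with a 1.1-fold higher number from compound 2 to compound 4 (0.03 log units; within the scatter). Nothing available explains either the order of the three groups or the lack of a clear core effect.

On these data alone, whether the core fluoro is equally silent alongside fluoro or methyl on the anilino ring remains open. Also open, as far as these compounds go, is where a methoxy, a bromo or an amine at this position would fall relative to these three groups.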